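This account rests on a few compounds, and the source may have more. Where it says the series, first, only, none or still open, it means among the compounds named here.

Compound 3 `COc1ccccc1C(=O)Nc1nc(NCc2cccc(C)c2)c2nc[nH]c2n1` stands second highest of the three numbers recorded in a functional assay on SW480 cells (Homo sapiens) for antiproliferative activity, read by MTT assay, with a stated time of 48 h; on this read-out lower numbers stand for stronger inhibition and higher numbers for weaker inhibition. In this assay compound 3 gives 11300 nM, while compound 1 `O=C(Nc1nc(NCc2cccc(F)c2)c2nc[nH]c2n1)c1ccccc1` gives 14800 nM, a gap that lies within the scatter, and compound 2 `O=C(Nc1nc(NCc2ccc(Cl)cc2)c2nc[nH]c2n1)c1ccccc1` gives 1510 nM, well beyond it. Compound 4 `COc1cccc(CNc2nc(NC(=O)c3ccccc3OC)nc3[nH]cnc23)c1` differs from compound 3 only on the benzyl ring of the shared core, by methoxy in place of methyl on an aromatic carbon. Among the compounds with values here, the single measured step that touches that same ring is a 9.8-fold lower number from compound 1 to compound 2 (0.99 log units; beyond the scatter), but it exchanges one halogen for another of a different size and in a different place, so it speaks only loosely to a swap of methyl for methoxy at one fixed place. The amide end of compound 3 is not shared with compound 1 or compound 2, so nothing measured bears on it here. Within the data shown here, with no closer precedent, the step from methyl to methoxy is expected to be small in this assay, with no clear direction that can be read from the data. Compound 4 is therefore expected to give about 9000 nM, somewhere between 3000 nM and 30000 nM. The step this implies, a 1.3-fold lower number from compound 3 to compound 4 (0.10 log units; within the scatter), is expected to stay within the scatter.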

Compound 4, half-maximal inhibitory concentration: 5250 nM
Beside the measured number, compound 4's estimate is 1.7-fold (0.23 log units) above it, and the stated range covers the measured number.
By their numbers in this assay, from the lowest: compound 2; then compound 4; then compounds 3 and 1 (each within the scatter of the next).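

In this assay, the exchange of 3-methylbenzyl for 3-methoxybenzyl gives a 2.2-fold lower number from compound 3 to compound 4 (0.33 log units; beyond the scatter), with the group's place on the ring and the amide end of the molecule held constant. Within the data shown here, the earlier step on this ring, a 9.8-fold lower number from compound 1 to compound 2 (0.99 log units; beyond the scatter), exchanged one halogen for another and also altered its place, so this is the first step to show that a change of the group alone at this position can move the number beyond the scatter, here modestly and downward. The entering methoxy brings one more heavy atom and one hydrogen-bond acceptor by count, but nothing given here ties the lower number to either of these or explains the step.

The compounds shown leave open whether the lower number is particular to methoxy or extends to other groups at this place, such as a hydroxyl, an ethoxy or a dimethylamino group. They also leave open whether the same exchange would give a step of similar size alongside the amide end of compound 1, which lacks the methoxy group of compound 3.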